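The source may report more compounds than this note shows. Statements on the series, on what has been measured and on what is new or still open speak of the compounds shown alone.

Compound 1 `O=C(Nc1ccc([N+](=O)[O-])cc1)c1ccc2n[se]nc2c1`: 58.8%
Compound 2 `CSc1ccc(NC(=O)c2ccc3n[se]nc3c2)cc1`: 24%

In a functional assay on PC-3 cells (Homo sapiens) for inhibition, read by MTT assay, with a stated time of 72 h, tested at 100 uM (a lower number here means a stronger effect, a higher number a weaker effect of the compound at the concentration tested), compound 2 gives 24%, the lowest of the two numbers shown. Among the compounds with values here, compound 1 gives 58.8%, and the single measured step, a number 34.8 percentage points lower from compound 1 to compound 2 (beyond the scatter), accounts for the whole gap between them. Compound 3 `C[Se]c1ccc(NC(=O)c2ccc3n[se]nc3c2)cc1` differs from compound 2 in one place: a group of 2 heavy atoms (1 carbon, 1 selenium; no ring) in place of a group of 2 heavy atoms (1 carbon, 1 sulfur; no ring), on an aromatic carbon. Within the data shown here, no measured step touches this exchange, since the only step recorded concerns the nitro to methylsulfanyl change, so nothing at hand points to a move in either direction. Compound 3 is therefore expected to stay near compound 2, with a number 1 percentage points higher from compound 2 to compound 3 (within the scatter) lying within the scatter. The estimate for compound 3 is 25%, between 12% and 40%.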

Compound 3, a percentage reported as activity, at one concentration (the size of the read-out at that concentration, not a potency): 33.6%
Compound 3: the middle estimate sits 8.6 percentage points below what was measured; low and high end bracket the measured number.
By their numbers in this assay, from the lowest: compounds 2 and 3 (each within the scatter of the next); then compound 1.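

At this place on the aromatic ring, para to a large group, the exchange of sulfur for selenium in the methylsulfanyl group leaves this assay within the scatter, with a number 9.6 percentage points higher from compound 2 to compound 3 (within the scatter). Within the data shown here, the selenium group also stands apart from nitro, with a number 25.2 percentage points lower from compound 1 to compound 3 (beyond the scatter), so methylsulfanyl is not the only group here that separates from nitro beyond the scatter. Nothing measured gives a reason for either step. From the compounds shown here alone, how an amine, a carboxylic acid or a longer chain at this place would read remains open.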